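Aryl versus arylmethyl substituents on the oxadiazole core

A few compounds are considered here, and "the series" means these few. Any claim that something is new, unique, unknown or untested is made for them only; others in the source may bear on it.

Measured so far:
compound 1 `O=C(c1ccc(-c2nc(-c3ccccn3)no2)s1)C(F)(F)F` 90 nM
compound 2 `Cc1ccc(-c2noc(-c3ccc(C(=O)C(F)(F)F)s3)n2)cc1` 110 nM
compound 3 `O=C(c1ccc(-c2nc(Cc3cccs3)no2)s1)C(F)(F)F` 15 nM

In an assay for inhibition of histone deacetylase 4 (Homo sapiens) (a lower number here means a stronger inhibitor, a higher number a weaker inhibitor), compound 3 gives the lowest number of the three, with a 6.0-fold lower number from compound 1 to compound 3 (0.78 log units; beyond the scatter) and a 7.3-fold lower number from compound 2 to compound 3 (0.87 log units; beyond the scatter) both beyond the scatter, while compound 1 and compound 2 sit within the scatter of each other.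

Compound 4 `O=C(c1ccc(-c2nc(-c3cccnc3)no2)s1)C(F)(F)F` carries pyridin-3-yl in place of (thiophen-2-yl)methyl on an aromatic carbon. This reverses the kind of change seen in the two measured steps: a directly attached six-membered aromatic ring replaces the one-carbon-linked five-membered ring. Both compound 1 and compound 2, with directly attached aromatic rings, gave roughly the same number, so compound 4 is expected to fall back toward that level, an increase of about a 6.3-fold higher number from compound 3 to compound 4 (0.80 log units; beyond the scatter). The estimate for compound 4 is 95 nM (range 40 nM to 250 nM).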

Compound 4, half-maximal inhibitory concentration: 70 nM
For compound 4 the middle estimate is 1.4-fold (0.13 log units) above the measured one, and the stated range covers the measured number.
By their numbers in this assay, from the lowest: compound 3; then compounds 4, 1 and 2 (each within the scatter of the next).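

In this assay the step of a 4.7-fold higher number from compound 3 to compound 4 (0.67 log units; beyond the scatter) shows that pyridin-3-yl does not keep the lower number seen with (thiophen-2-yl)methyl at this position. The steps of a 1.3-fold lower number from compound 1 to compound 4 (0.11 log units; within the scatter) and a 1.6-fold lower number from compound 2 to compound 4 (0.20 log units; within the scatter) both stay within the scatter, so the three directly attached six-membered rings cannot be told apart here. Nothing available explains the gap to compound 3.

Compound 3 differs from the others in both its one-carbon link and its five-membered ring, so either could carry the gap. A benzyl group or a directly attached thiophen-2-yl would separate the two.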